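Longer ester chain in compound 4: a small step expected

The source may hold more compounds than are shown below. What is called first, only, known or untested is meant among the compounds shown, and "the series" means these compounds.

Three compounds share one core and have been measured in a functional assay on A549 cells (Homo sapiens) for cytotoxicity, read by MTT assay, with a stated time of 24 h, tested at 80 uM; on this read-out lower numbers stand for a stronger effect and higher numbers for a weaker effect at the one concentration tested:
- compound 1 `CCCOC(=O)CCC(=O)N1CCN(CCCOc2cc3c(Nc4ccc(F)c(Cl)c4)ncnc3cc2OC)CC1` gives 23.4%
- compound 2 `CCCCCCCCCOC(=O)CCC(=O)N1CCN(CCCOc2cc3c(Nc4ccc(F)c(Cl)c4)ncnc3cc2OC)CC1` gives 7.8%
- compound 3 `CCCCCCCCCCOC(=O)CCC(=O)N1CCN(CCCOc2cc3c(Nc4ccc(F)c(Cl)c4)ncnc3cc2OC)CC1` gives 2%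

Compound 3 gives the lowest of the three numbers. Its distance from compound 1 is a number 21.4 percentage points lower from compound 1 to compound 3 (beyond the scatter), while the step of a number 5.8 percentage points lower from compound 2 to compound 3 (within the scatter) lies within the scatter, so compound 2 and compound 3 cannot be told apart on this read-out.

Compound 4 `CCCCCCCCCCCCCCCCOC(=O)CCC(=O)N1CCN(CCCOc2cc3c(Nc4ccc(F)c(Cl)c4)ncnc3cc2OC)CC1` differs from compound 3 by hexyl in place of hydrogen on a saturated chain carbon, ten or more bonds along the chain from an oxygen next to a carbonyl group. The same group entering the chain has been seen once, in the step of a number 15.6 percentage points lower from compound 1 to compound 2 (beyond the scatter), and a shorter addition further along the chain gave a number 5.8 percentage points lower from compound 2 to compound 3 (within the scatter). Because compound 3 already gives 2%, there is little room for a further fall, and a step of a number 0.5 percentage points lower from compound 3 to compound 4 (within the scatter) is expected, which stays within the scatter. Compound 4 is therefore estimated at 1.5%, with a range from 0% to 9%.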

Compound 4, a percentage reported as activity, at one concentration (the size of the read-out at that concentration, not a potency): 74.3%
Beside the measured number, compound 4's estimate is 72.8 percentage points below it; measured number above the stated range.
By their numbers in this assay, from the lowest: compounds 3 and 2 (each within the scatter of the next); then compound 1; then compound 4.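

In this assay, adding carbon to the ester chain does not keep lowering the number: hexyl entering the chain gives a number 72.3 percentage points higher from compound 3 to compound 4 (beyond the scatter), and heptyl entering nine bonds along the chain gives a number 66.5 percentage points higher from compound 2 to compound 4 (beyond the scatter). The downward run across compound 1, compound 2 and compound 3 therefore does not extend to compound 4, which goes against it and prints a higher number than compound 1, the shortest chain shown. The effect of adding to this chain thus depends on the chain it joins, as the same hexyl addition shows: the same change on two cores in this assay, a number 15.6 percentage points lower (beyond the scatter) from compound 1 to compound 2 and a number 72.3 percentage points higher (beyond the scatter) from compound 3 to compound 4, 87.9 percentage points apart, beyond the scatter of two such steps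

The compounds shown do not tell why the number rises, nor where between the chains of compound 3 and compound 4 the turn lies. As far as these compounds go, it also remains open how a branched alkyl chain or a terminal carboxylic acid at this position would read.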